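Dimethylphenyl Variant in a Weakly Antiproliferative Spiro Series

This account rests on a few compounds, and the source may have more. Where it says the series, first, only, none or still open, it means among the compounds named here.

Compound 3 `N#CC1=C(N)Oc2c(c3nc4ccccc4nc3c3ccccc23)C12C(=O)N(Cc1cnnn1-c1ccc(N)cc1)c1ccccc12` belongs to a small set of spiro compounds examined in a functional assay on A549 cells (Homo sapiens) for antiproliferative activity, read by MTT assay, with a stated time of 48 h; a higher number here means a weaker inhibitor, a lower number a stronger inhibitor. In this assay compound 3 reaches only the limit > 50000 nM, so no number is known for it. Compound 1 `N#CC1=C(N)Oc2c(c3nc4ccccc4nc3c3ccccc23)C12C(=O)N(Cc1cnnn1-c1ccccc1Cl)c1ccccc12` gives 42600 nM in this assay. Compound 2 `N#CC1=C(N)Oc2c(c3nc4ccccc4nc3c3ccccc23)C12C(=O)N(Cc1cnnn1-c1ccccc1Br)c1ccccc12` likewise stops at the limit > 50000 nM. Among the measured compounds shown here, the evidence thus rests on (the limit of > 50000 nM in this assay, at which 2 of the 3 values shown sit), with compound 1 the only compound that yields a number at all.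

The change leading to compound 4 `Cc1ccc(-n2nncc2CN2C(=O)C3(C(C#N)=C(N)Oc4c3c3nc5ccccc5nc3c3ccccc43)c3ccccc32)c(C)c1` is 2,4-dimethylphenyl in place of 4-aminophenyl on an aromatic nitrogen. For the measured compounds named here, three measured steps concern the substituent on the aromatic nitrogen of the five-membered ring with three nitrogens: an at least 1.1-fold higher number from compound 1 to compound 2 (0.06 log units; that floor lies within the scatter), an at least 1.1-fold higher number from compound 1 to compound 3 (0.06 log units; that floor lies within the scatter) and a step that the two limits leave unreadable from compound 2 to compound 3. Going by the values given here, none of them reveals a readable step, and the one number available lies close to the limit itself. Exchanging the group on that nitrogen for a 2,4-dimethylphenyl is therefore expected to leave compound 4 in the same weak range, with no step beyond the scatter, that is a number no higher from compound 3 to compound 4 (the limit leaves the size open). Compound 4 is expected to show about 50000 nM in this assay, within a range from 25000 nM to 150000 nM, and it may well again be reported only as a limit.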

Compound 4, half-maximal inhibitory concentration: > 50000 nM
Compound 4: no number, only a limit (the forecaster's own chance of this, stated with the estimate: 65%); the middle value lies on the limit itself.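

Compound 4 is a third compound in this series that gives only a limit in this assay. The 2,4-dimethylphenyl has 0 hydrogen-bond donors and 0 hydrogen-bond acceptors, whereas the 4-aminophenyl it replaces has 1 of each, yet this exchange on the aromatic nitrogen produces no number that could be compared with compound 3. Compared with compound 1, the only compound with a number, the change gives an at least 1.1-fold higher number from compound 1 to compound 4 (0.06 log units; that floor lies within the scatter), so nothing separates the two, and the steps to compound 4 from compound 2 and compound 3 cannot be read because limits stand at both ends: the limit of > 50000 nM in this assay, at which 3 of the 4 values shown sit.

The compounds shown leave open whether any group on this nitrogen can bring a value clearly into the measurable range, since they carry only substituted phenyl rings there, and a carboxylic acid on that ring or a longer alkyl chain in its place is not among them. They also leave open whether a change elsewhere on the shared core would do more than any exchange at this position.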